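Removing the chloro from compound 1: what to expect

The source may report more compounds than this note shows. Statements on the series, on what has been measured and on what is new or still open speak of the compounds shown alone.

Compound 1 `CCCCn1cnc2c(Nc3cccc(Cl)c3)nc(NCOCc3ccc(/C=C/C(=O)Nc4ccccc4N)cc3)nc21` was tested in a functional assay on NCI-H460 cells (Homo sapiens) for antiproliferative activity, read by CCK-8 assay, with a stated time of 72 h, tested at 2 uM (on this read-out higher numbers stand for a stronger effect at the one concentration tested and lower numbers for a weaker effect), where compound 1 gives 25.7%. Among the three measured compounds, compound 1 stands lowest. Compound 2 `Nc1ccccc1NC(=O)/C=C/c1ccc(COCNc2nc(Nc3cccc(Cl)c3)c3ncn(C4CCCC4)c3n2)cc1` gives 37.1% in this assay, and compound 3 `CC(C)n1cnc2c(Nc3cccc(Cl)c3)nc(NCOCc3ccc(/C=C/C(=O)Nc4ccccc4N)cc3)nc21` gives 53%. The measured steps all concern the group on the aromatic nitrogen: a number 11.4 percentage points higher from compound 1 to compound 2 (beyond the scatter), a number 27.3 percentage points higher from compound 1 to compound 3 (beyond the scatter) and a number 15.9 percentage points higher from compound 2 to compound 3 (beyond the scatter), each a modest shift beyond the scatter.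

Compound 4 `CCCCn1cnc2c(Nc3ccccc3)nc(NCOCc3ccc(/C=C/C(=O)Nc4ccccc4N)cc3)nc21` differs from compound 1 elsewhere: hydrogen in place of chloro on an aromatic carbon. Among the measured compounds shown here, the change sits on an aromatic carbon of a six-membered aromatic ring of carbon only, meta to a large group, and none of the measured steps touches this position, so no step bears on it directly. What the measured steps show is that single changes in this series move the read-out by modest amounts. Without a comparable precedent, he expects no step beyond the scatter, with a number 2.7 percentage points lower from compound 1 to compound 4 (within the scatter) as the estimated shift. He therefore estimates that compound 4 gives 23% in this assay, within a range from 8% to 40%.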

Compound 4, a percentage reported as inhibition, at one concentration (the size of the read-out at that concentration, not a potency): 23.1%
Estimate against measurement, compound 4: 0.1 percentage points below; the measured number falls inside the stated range.
By their numbers in this assay, from the lowest: compounds 4 and 1 (each within the scatter of the next); then compound 2; then compound 3.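

The change from 3-chlorophenyl to phenyl gives a number 2.6 percentage points lower from compound 1 to compound 4 (within the scatter) in this assay, so with butyl on the aromatic nitrogen the chloro can be replaced by hydrogen without a shift that stands out from the usual scatter. Whereas each measured step on the aromatic nitrogen lies beyond the scatter, this first step on an aromatic carbon of the six-membered ring does not, and compound 4 and compound 1 cannot be told apart at the one concentration tested. Nothing available here explains this result.

The compounds shown leave open whether hydrogen in place of chloro would also stay within the scatter with isopropyl or cyclopentyl on the aromatic nitrogen. They also leave open what a methoxy group, an amine or a carboxylic acid would do in place of the chloro.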